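Trimming a Fused Ring in Search of Solubility

The source may hold more compounds than are shown below. What is called first, only, known or untested is meant among the compounds shown, and "the series" means these compounds.

Measured so far:
- compound 1 `O=C(CCSc1nc2ccccc2c(=O)[nH]1)N[C@H]1CC[C@H](c2nnc(-c3ccccc3)o2)CC1`: 7 ug/mL
- compound 2 `O=C(CSc1nc2ccccc2c(=O)[nH]1)N[C@H]1CC[C@H](c2nnc(-c3ccccc3)o2)CC1`: 1 ug/mL

Both measured compounds share a core and differ only in the length of the chain on the sulfur. In an ADME assay for solubility, in simulated intestinal fluid, at pH 6.8 (on this read-out higher numbers stand for higher solubility and lower numbers for lower solubility), compound 1 gives 7 ug/mL, the higher of the two numbers. Compound 2 gives 1 ug/mL in this assay, and the gap between the two lies beyond the usual scatter, so compound 1 is the more soluble of the pair.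

Compound 3 `O=C(CCSc1nccc(=O)[nH]1)N[C@H]1CC[C@H](c2nnc(-c3ccccc3)o2)CC1` has not yet been measured. It keeps the longer chain of compound 1 and changes one place: a group of 7 heavy atoms (4 carbon, 2 nitrogen, 1 oxygen; one six-membered aromatic ring with 2 hetero atoms) in place of a group of 11 heavy atoms (8 carbon, 2 nitrogen, 1 oxygen; one six-membered aromatic ring of carbon only, one six-membered aromatic ring with 2 hetero atoms), on a sulfur. The ring of carbon only is gone, and the group on the sulfur is smaller.

Within the data shown here, no pair of measured compounds shows what such a change does in this assay, so the expectation is a guess guided by the size of the group that leaves. The step of a 2.9-fold higher number from compound 1 to compound 3 (0.46 log units; beyond the scatter) is expected to be upward, of modest size, with a real chance that it stays within the scatter. Compound 3 is estimated at 20 ug/mL, with a likely range from 6 ug/mL to 70 ug/mL.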

Compound 3, solubility: 53 ug/mL
For compound 3 the middle estimate is 2.7-fold (0.42 log units) below the measured one, within the range that was stated.
By their numbers in this assay, from the lowest: compound 2; then compound 1; then compound 3.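

With the longer chain left in place, replacing the group on the sulfur gives a 7.6-fold higher number from compound 1 to compound 3 (0.88 log units; beyond the scatter) in this assay and shows that this group, not only the chain, can move the number. Among these compounds, the step is beyond the usual scatter, and it is the first measured step at this position, as the earlier pair differed only in the length of the chain. The group that leaves and the group that enters carry the same counts of hydrogen-bond donors and acceptors, so the difference between them lies in the six-membered aromatic ring of carbon only and the smaller size, yet no measurement here explains the rise.

The compounds shown do not tell whether the same replacement would give a step of similar size on the shorter chain of compound 2. They also leave open what an added group on the remaining ring, such as an amine or a carboxylic acid, would do to the number in this assay and whether the gain would hold.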